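Trading the aryl group for a fluoro on the oxazole

The compounds below may be only part of what the source reports. "The series", "measured", "known", "first", "only" and "open" are said of these compounds alone.

Two ketone inhibitors have been measured in an assay (Rattus norvegicus) for inhibition of Fatty-acid amide hydrolase 1 (Homo sapiens); a higher number here means a weaker inhibitor, a lower number a stronger inhibitor. Compound 1, `NS(=O)(=O)c1ccccc1-c1cnc(C(=O)CCCCCCc2ccccc2)o1`, gives 1500 nM in this assay. Compound 2, `Cc1ccnc(-c2cnc(C(=O)CCCCCCc3ccccc3)o2)c1`, gives 0.6 nM in this assay, the lower of the two numbers, and it lies far below compound 1, a gap well beyond the usual scatter. Compound 3, `O=C(CCCCCCc1ccccc1)c1ncc(F)o1`, has not been measured. It differs from compound 2 by fluoro in place of 4-methylpyridin-2-yl on an aromatic carbon, the new fluoro sitting on the same aromatic carbon of the five-membered ring that in compound 2 carries the 4-methylpyridin-2-yl group. Among the measured compounds shown here, no measured pair separates this change on its own, so the step can only be anticipated. The large group that leaves is expected to matter, and the number is estimated to rise by a 250-fold higher number from compound 2 to compound 3 (2.40 log units; beyond the scatter), beyond the scatter. Compound 3 is therefore expected to give about 150 nM in this assay, within roughly 30 nM to 800 nM.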

Compound 3, inhibition constant: 30 nM
Compound 3: the middle estimate sits 5.0-fold (0.70 log units) above what was measured, within the range that was stated.
By their numbers in this assay, from the lowest: compound 2; then compound 3; then compound 1.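

In this assay the change at this carbon, next to the ring oxygen, gives a 50-fold higher number from compound 2 to compound 3 (1.70 log units; beyond the scatter) and so costs a large part of the potency of compound 2. Even so, the 4-methylpyridin-2-yl group is not needed for strong inhibition: with only a fluoro there, compound 3 gives 30 nM and stays well under the number of compound 1, which gives 1500 nM with its aryl group in the same place. No measurement available here explains the size of this step.

The compounds shown leave open whether the gain in compound 2 rests on the pyridine ring nitrogen, the methyl or the ring as a whole, which an unsubstituted phenyl or pyridin-2-yl group would help to separate. They also leave open how a chloro, a nitrile or a carboxylic acid would fare on this carbon.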